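Working notes on cytotoxicity in a small series

The compounds below may be only part of what the source reports. "The series", "measured", "known", "first", "only" and "open" are said of these compounds alone.

Measured so far:
compound 1, `CCC1(Cc2ccccc2)OS(=O)(=O)CC1=O`: > 100000 nM
compound 2, `CCC1(Cc2ccccc2)OS(=O)(=O)C=C1OCc1ccc(OC)cc1`: >= 200000 nM
compound 3, `CC(C)CC1(Cc2ccccc2)OS(=O)(=O)C=C1OCc1ccccc1`: >= 80000 nM

In an ADME assay on HEL cells (Homo sapiens) for cytotoxicity, with a stated time of 3 days (on this read-out higher numbers stand for lower toxicity in this test and lower numbers for higher toxicity in this test), compound 2 gives >= 200000 nM, which is a limit of the assay and not a number (the limit of >= 200000 nM in this assay, at which 1 of the 3 values shown sits). Compound 1 gives > 100000 nM, also a limit (the limit of > 100000 nM in this assay, at which 1 of the 3 values shown sits). Compound 3 gives >= 80000 nM, again a limit (the limit of >= 80000 nM in this assay, at which 1 of the 3 values shown sits). Within the data shown here, no two of the measured compounds differ in a single place, so no step among them can be read; the three values show only that each sits at its own limit.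

Compound 4, `CCC1(Cc2ccccc2)OS(=O)(=O)C=C1OCc1ccc(Br)cc1`, differs from compound 2 by bromo in place of methoxy on an aromatic carbon. The step of a number no higher from compound 2 to compound 4 (the limit leaves the size open) is expected to stay within the scatter, with compound 4 again most likely reported only as a limit. For compound 4 the estimate is 200000 nM, between 80000 nM and 500000 nM.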

Compound 4, minimum cytotoxic concentration: 80000 nM
Estimate against measurement, compound 4: 2.5-fold (0.40 log units) above; the range from low to high includes it.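

In this assay, among these compounds, compound 4 gives 80000 nM, the first value that is a number and not a limit. Bromo in place of methoxy on an aromatic carbon, para to a large group, gives an at least 2.5-fold lower number from compound 2 to compound 4 (0.39 log units; beyond the scatter), so this position does register on this read-out. The full size of that step stays open, since compound 2 stands at a limit: the limit of >= 200000 nM in this assay, at which 1 of the 4 values shown sits.

On these data alone, whether an amine or a carboxylic acid at this position would lower the number further remains open. So does whether the same change would act alike on the core of compound 3.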